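A few compounds are considered here, and "the series" means these few. Any claim that something is new, unique, unknown or untested is made for them only; others in the source may bear on it.

Two members of the series have been measured in a functional assay on CCRF-CEM cells (Homo sapiens) for inhibition, read by MTT assay, with a stated time of 2 days, tested at 10 uM; a lower number here means less inhibition, a higher number more inhibition at the concentration tested (going by the name of the read-out). Compound 1 `COc1ccccc1-c1cn(-c2ccc(O)c(C(=O)Nc3cccc(C(F)(F)F)c3)c2)nn1` gives 65%. Compound 2 `COc1cc(OC)cc(-c2cn(-c3ccc(O)c(C(=O)O)c3)nn2)c1` gives 9%, the lower of the two numbers, with compound 1 standing higher by more than the scatter. Compound 3 `COc1cc(OC)cc(-c2cn(-c3ccc(O)c(C(=O)Nc4cccc(C(F)(F)F)c4)c3)nn2)c1` is not yet measured; it differs from compound 2 by (3-(trifluoromethyl)phenyl)amino in place of hydroxy on a carbonyl carbon. Because compound 1 carries the same group on its carbonyl carbon and gives 65%, the step of a number 46 percentage points higher from compound 2 to compound 3 (beyond the scatter) is expected to be a rise beyond the scatter. Compound 3 is estimated at 55%, within 30% to 80%.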

Compound 3, a percentage reported as inhibition, at one concentration (the size of the read-out at that concentration, not a potency): 73%
Compound 3: the middle estimate sits 18 percentage points below what was measured; the measured number falls inside the stated range.
By their numbers in this assay, from the lowest: compound 2; then compounds 1 and 3 (each within the scatter of the next).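

With the rest of the molecule held constant, (3-(trifluoromethyl)phenyl)amino in place of hydroxy on the carbonyl carbon gives, in this assay, a number 64 percentage points higher from compound 2 to compound 3 (beyond the scatter) and so links the amide directly to the higher reading. With that amide present, 3,5-dimethoxyphenyl in place of 2-methoxyphenyl on an aromatic carbon gives a number 8 percentage points higher from compound 1 to compound 3 (within the scatter), so these two aryl groups cannot be told apart here. Nothing at hand explains the large step. The compounds shown leave open how a methyl ester or a plain phenylamino group on that carbonyl carbon would read. They also leave open whether the trifluoromethyl group is needed for the higher reading.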